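This account rests on a few compounds, and the source may have more. Where it says the series, first, only, none or still open, it means among the compounds named here.

Working notes on the series. Compound 2 `CCn1cc(-c2nc3ccc(N)cc3[nH]2)c(=O)c2cc(F)c(N3CCNCC3)cc21` in a functional assay on KB cells (Homo sapiens) for cytotoxicity, read by MTT assay, with a stated time of 48 h (a lower number here means a stronger inhibitor, a higher number a weaker inhibitor), gives 35400 nM. Compound 1 `CCn1cc(-c2nc3ccccc3s2)c(=O)c2cc(F)c(N3CCN(C)CC3)cc21` in this assay gives 19000 nM; the two values lie within the usual scatter of each other, so compound 2 stands together with compound 1 at the weak end of what has been measured, and nothing separates them. Compound 3 `CCn1cc(-c2nc3ccc(N)cc3[nH]2)c(=O)c2cc(F)c(N3CCN(C)CC3)cc21` is not yet measured. Compound 3 differs from compound 2 by methyl in place of hydrogen on an amine nitrogen in a ring, a change in one place only. For the measured compounds named here, no step between measured compounds in this assay covers this change, so no size beyond the scatter is expected, in either direction. Compound 3 is expected to give about 30000 nM in this assay, plausibly between 12000 nM and 75000 nM, an estimated step of a 1.2-fold lower number from compound 2 to compound 3 (0.07 log units; within the scatter).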

Compound 3, half-maximal inhibitory concentration: > 50000 nM
Compound 3 gave a limit, no number; the forecaster's own chance of this, stated with the estimate: 10%; middle value at least 1.6-fold (0.22 log units) from the limit.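

Compound 3 reads only as a limit of the assay, not as a number: the limit of > 50000 nM in this assay, at which 1 of the 3 values shown sits. At the amine nitrogen in the ring, 4-methylpiperazin-1-yl in place of piperazin-1-yl gives an at least 1.4-fold higher number from compound 2 to compound 3 (0.14 log units; that floor lies within the scatter), so this change is not resolved from the scatter, and its true size cannot be read. With 4-methylpiperazin-1-yl held constant, the change on the aromatic carbon gives the first separation in the series, an at least 2.6-fold higher number from compound 1 to compound 3 (0.42 log units; beyond the scatter), in this assay. The compounds shown leave open whether an ethyl group or a longer chain on that ring nitrogen would give a measurable number.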